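Methyl for fluoro on compound 1

The source may hold more compounds than are shown below. What is called first, only, known or untested is meant among the compounds shown, and "the series" means these compounds.

Compound 1 (`Cc1cc(C(=O)O)cc(C)c1NC(=O)c1cc(-c2cccc(CO)c2)ccc1F`) gives 12% in an ADME assay on the whole organism for pharmacokinetics, with Rattus norvegicus as the target, at a dose of 5 mg/kg by the oral route (on this read-out lower numbers stand for lower oral bioavailability and higher numbers for higher oral bioavailability), and lies within the scatter of compound 2 (`Cc1ccc(C(=O)O)c(C)c1NC(=O)c1cc(-c2cccc(CO)c2)ccc1F`) at 11% and of compound 3 (`Cc1ccc(-c2cccc(CO)c2)cc1C(=O)Nc1c(C)ccc(C(=O)O)c1C`) at 7% on the same read-out. Compound 4 (`Cc1ccc(-c2cccc(CO)c2)cc1C(=O)Nc1c(C)cc(C(=O)O)cc1C`) carries methyl in place of the fluoro of compound 1, on an aromatic carbon para to a 3-(hydroxymethyl)phenyl group (methyl in place of fluoro on an aromatic carbon). One measured step involves the same swap: a number 4 percentage points lower from compound 2 to compound 3 (within the scatter) and it stays within the scatter. No step beyond the scatter is therefore expected in this assay here. The expected step is a number 4 percentage points lower from compound 1 to compound 4 (within the scatter) and it would also lie within the scatter. Compound 4 is estimated at 8% with an expected range from 3% to 16% in this measurement.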

Compound 4, oral bioavailability: 13%
Estimate against measurement, compound 4: 5 percentage points below; measured number inside the range.
By their numbers in this assay, from the lowest: compounds 3, 2, 1 and 4 (each within the scatter of the next).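

In this assay, methyl in place of fluoro gives a number 1 percentage points higher from compound 1 to compound 4 (within the scatter), so the swap at this position, para to a 3-(hydroxymethyl)phenyl group, now has a reading on a second core. On both cores it stays within the scatter, and the two cores cannot be told apart on this change: the same change on two cores in this assay, a number 4 percentage points lower (within the scatter) from compound 2 to compound 3 and a number 1 percentage points higher (within the scatter) from compound 1 to compound 4, 5 percentage points apart, within the scatter of two such steps

As far as these compounds go, whether another group at this position, such as chloro, methoxy or an amine, would give a step beyond the scatter remains open. So does whether either core could reach a clearly different number in this assay.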